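A few compounds are considered here, and "the series" means these few. Any claim that something is new, unique, unknown or untested is made for them only; others in the source may bear on it.

The compounds measured so far:

Compound 1 `COc1ccc(-c2cc3nccc(-c4cc(OC)c(OC)c(OC)c4)n3n2)cc1N` gives 88 nM in a functional assay on B16-F0 cells (Mus musculus) for inhibition, read by CCK-8 assay, with a stated time of 48 h; a higher number here means a weaker inhibitor, a lower number a stronger inhibitor.
Compound 2 `COc1ccc(-c2cc3nccc(-c4cc(OC)c(OC)c(OC)c4)n3n2)cc1[N+](=O)[O-]` reaches only the limit of > 10000 nM in this assay, so no number is known for it.
Compound 3 `COc1cc(-c2ccnc3cc(-c4ccc(C(C)=O)cc4)nn23)cc(OC)c1OC` gives 3930 nM in this assay.

Among the two numbers, compound 3 has the highest, and its nearest neighbour is compound 1, reached by the step of a 45-fold higher number from compound 1 to compound 3 (1.65 log units; beyond the scatter). Compound 4 `COc1ccc(-c2cc3nccc(-c4cc(OC)c(OC)c(OC)c4)n3n2)cc1F` has not been measured. It differs from compound 3 in one place: 3-fluoro-4-methoxyphenyl in place of 4-acetylphenyl on an aromatic carbon. The new group brings back much of the group of compound 1, with fluorine where compound 1 has an amino group. Among the compounds with values here, two measured steps bear on this. The step of a 45-fold higher number from compound 1 to compound 3 (1.65 log units; beyond the scatter) shows that removing the 3-amino-4-methoxyphenyl group costs a great deal, and the step of an at least 110-fold higher number from compound 1 to compound 2 (2.05 log units; beyond the scatter) shows that the amino group itself matters, since nitro in its place gives only a limit. Compound 4 is therefore expected to sit between compound 1 and compound 3, with the step of a 9.8-fold lower number from compound 3 to compound 4 (0.99 log units; beyond the scatter) toward stronger inhibition. The estimate for compound 4 in this assay is 400 nM, with a likely range from 80 nM to 2500 nM.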

Compound 4, half-maximal inhibitory concentration: 3950 nM
Estimate against measurement, compound 4: 9.9-fold (0.99 log units) below, and the stated range ends below it.
By their numbers in this assay, from the lowest: compound 1; then compounds 3 and 4 (each within the scatter of the next). At a limit, above all of these: compound 2.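

In this assay, fluoro in place of the amino group gives a 45-fold higher number from compound 1 to compound 4 (1.65 log units; beyond the scatter), so keeping the rest of the 3-amino-4-methoxyphenyl group of compound 1 is not enough to keep its low number. Within the data shown here, the 3-fluoro-4-methoxyphenyl group and the 4-acetylphenyl group cannot be told apart here, with a 1.0-fold higher number from compound 3 to compound 4 (0.00 log units; within the scatter), even though only the first resembles the group of compound 1. The step with nitro, an at least 2.5-fold lower number from compound 2 to compound 4 (0.40 log units; beyond the scatter), rests on a limit for compound 2 and so gives only a minimum size: the limit of > 10000 nM in this assay, at which 1 of the 4 values shown sits.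

The compounds shown leave open whether any group other than amino can serve in that place. A hydroxyl group, a methylamino group or an acetamide there would show how narrowly the low number depends on the amino group itself.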